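Replacing sec-butyl with carboxymethyl in compound 3

The compounds below may be only part of what the source reports. "The series", "measured", "known", "first", "only" and "open" are said of these compounds alone.

Compound 1 `C#CC(C)OC(=O)c1ccc(C(CC)(CC)c2ccc(OCCC(O)(CC)CC)c(C)c2)n1CC`: > 50000 nM, a limit
Compound 2 `CCOc1ccc(NC(=O)c2ccc(C(CC)(CC)c3ccc(OCCC(O)(CC)CC)c(C)c3)n2CC)cc1`: > 50000 nM, a limit
Compound 3 `CCC(C)C(NC(=O)c1ccc(C(CC)(CC)c2ccc(OCCC(O)(CC)CC)c(C)c2)n1CC)C(=O)OC`: > 50000 nM, a limit

All three were measured in an ADME assay on L02 cells (Homo sapiens) for antiproliferative activity, read by MTT assay, with a stated time of 48 h (on this read-out higher numbers stand for weaker inhibition and lower numbers for stronger inhibition), and none of them gives an exact number. Compound 3 shares (the limit of > 50000 nM in this assay, at which 3 of the 3 values shown sit). Compound 4 `CCn1c(C(=O)NC(CC(=O)O)C(=O)OC)ccc1C(CC)(CC)c1ccc(OCCC(O)(CC)CC)c(C)c1` differs from compound 3 as follows: carboxymethyl in place of sec-butyl on a saturated chain carbon bound to an amide-type nitrogen and a carbonyl carbon. The measured steps that bear on this change are a step that the two limits leave unreadable from compound 1 to compound 3 and a step that the two limits leave unreadable from compound 2 to compound 3. Neither gives a size to carry over, so no step beyond the scatter is expected in this assay, and no direction can be stated. The expected step is a step that the limit leaves unreadable from compound 3 to compound 4. Compound 4 is estimated at 60000 nM, with an expected range of 30000 nM to 120000 nM.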

Compound 4, half-maximal inhibitory concentration: 7590 nM
Beside the measured number, compound 4's estimate is 7.9-fold (0.90 log units) above it; the whole stated range lies above it.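

In this assay carboxymethyl in place of sec-butyl on a saturated chain carbon bound to an amide-type nitrogen and a carbonyl carbon gives an at least 6.5-fold lower number from compound 3 to compound 4 (0.81 log units; beyond the scatter) and so a readable step at this position. Compound 4 also reads against the other two, with an at least 6.5-fold lower number from compound 2 to compound 4 (0.81 log units; beyond the scatter) and with an at least 6.5-fold lower number from compound 1 to compound 4 (0.81 log units; beyond the scatter) as well, whereas the steps among compound 1, compound 2 and compound 3 cannot be read. Compound 1, compound 2 and compound 3 each stay at a limit: the limit of > 50000 nM in this assay, at which 3 of the 4 values shown sit.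

The compounds shown leave open the full size of these steps. They also leave open how an aminomethyl group or a longer carboxyethyl chain would read at this place.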